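The source may hold more compounds than are shown below. What is called first, only, known or untested is meant among the compounds shown, and "the series" means these compounds.

In a functional assay on SK-OV-3 cells (Homo sapiens) for antiproliferative activity, read by MTT assay, with a stated time of 24 h (a higher number here means a weaker inhibitor, a lower number a stronger inhibitor), compound 1 `COc1ccc(C(=O)/C=C/c2ccc([N+](=O)[O-])cc2)c2c1C=CC(C)(C)O2`, which carries 4-nitrophenyl, gives 3420 nM. Compound 2 `COc1ccc(/C=C/C(=O)c2ccc(OC)c3c2OC(C)(C)C=C3)cn1`, with 6-methoxypyridin-3-yl in that place, reads > 10000 nM, which is a limit and not a number. Compound 3 `COc1ccc(C(=O)/C=C/c2ccsc2)c2c1C=CC(C)(C)O2`, with thiophen-3-yl there, reads > 10000 nM, and this too is only a limit. Compound 3 therefore has no number of its own and stands at the limit of > 10000 nM in this assay, at which 2 of the 3 values shown sit.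

Compound 4 `COc1ccc(C(=O)/C=C/c2ccco2)c2c1C=CC(C)(C)O2` differs from compound 3 in one place, with furan-2-yl in place of thiophen-3-yl on a double-bonded chain carbon bound to a double-bonded chain carbon. The measured steps bear on this change only indirectly. Two of them lead away from 4-nitrophenyl: an at least 2.9-fold higher number from compound 1 to compound 2 (0.46 log units; beyond the scatter), and an at least 2.9-fold higher number from compound 1 to compound 3 (0.46 log units; beyond the scatter). Both are beyond the scatter, and both are floors rather than sizes. Within the data shown here, the third, a step that the two limits leave unreadable from compound 2 to compound 3, is the only one between two groups other than 4-nitrophenyl, and it gives no size. Among the measured compounds shown here, no measured step exchanges one five-membered aromatic ring for another.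

No clear change is therefore expected in this assay, and compound 4 will most likely remain near the limit reached by compound 3. The expected change is a step that the limit leaves unreadable from compound 3 to compound 4. For compound 4 the estimate is 11000 nM, with an expected range from 4000 nM to 30000 nM.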

Compound 4, half-maximal inhibitory concentration: > 10000 nM
Compound 4 gave a limit, no number; the forecaster's own chance of this, stated with the estimate: 65%; the middle value is on the limit's open side.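

In this assay, furan-2-yl in place of thiophen-3-yl on a double-bonded chain carbon bound to a double-bonded chain carbon leaves compound 4 with a limit and no number, so this change does not bring the series back to a readable value: the limit of > 10000 nM in this assay, at which 3 of the 4 values shown sit. A second five-membered aromatic ring with one hetero atom, now oxygen where compound 3 has sulfur, therefore ends up on the same side of the limit, and the step from the nitro-bearing compound is again only a floor: an at least 2.9-fold higher number from compound 1 to compound 4 (0.46 log units; beyond the scatter). The steps that link compound 4 to compound 2 and to compound 3 cannot be read, and compound 1, with 4-nitrophenyl, goes against the pattern as the only one of the four with a number of its own.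

The compounds shown leave open how compound 2, compound 3 and compound 4 rank among themselves, since all three rest on limits. They also leave open whether a phenyl ring carrying an amine or a carboxylic acid in this place, rather than the nitro group of 4-nitrophenyl, would give a number in this assay.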